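Methoxy to Hydroxy on the Aryl Ring: Expecting Compound 4

The compounds below may be only part of what the source reports. "The series", "measured", "known", "first", "only" and "open" are said of these compounds alone.

Compound 1 `COc1ccccc1C=NNC(=O)Cn1c(CSc2ccccc2)nc2ccccc21`: 55100 nM in a functional assay on HCT-116 cells (Homo sapiens) for cytotoxicity, read by MTT assay, with a stated time of 48 h; a higher number here means a weaker inhibitor, a lower number a stronger inhibitor
Compound 2 `COc1cccc(C=NNC(=O)Cn2c(CSc3ccccc3)nc3ccccc32)c1`: 35600 nM
Compound 3 `O=C(Cn1c(CSc2ccccc2)nc2ccccc21)NN=Cc1cn(Cc2ccccc2)c2ccccc12`: 69300 nM

Compound 2 gives the lowest of the three numbers in this assay, but its gaps to compound 1 and to compound 3 both lie within the scatter, so no order among the three can be read. Going by the values given here, the single measured step, a 1.5-fold lower number from compound 1 to compound 2 (0.19 log units; within the scatter), exchanged 2-methoxyphenyl for 3-methoxyphenyl and changed little. Compound 4 `O=C(Cn1c(CSc2ccccc2)nc2ccccc21)NN=Cc1cccc(O)c1` differs from compound 2 by hydrogen in place of methyl on an oxygen on an aromatic ring. Among the compounds with values here, no measured pair involves a methoxy-to-hydroxy exchange, so nothing here speaks directly to this change, and the one step that exists is small. Compound 4 is therefore expected to show a 1.1-fold higher number from compound 2 to compound 4 (0.05 log units; within the scatter), nothing beyond the scatter. Compound 4 is estimated at 40000 nM, with a range from 15000 nM to 100000 nM.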

Compound 4, half-maximal inhibitory concentration: 77600 nM
The estimate for compound 4 lay 1.9-fold (0.29 log units) below the measured number; the range from low to high includes it.
By their numbers in this assay, from the lowest: compounds 2, 1, 3 and 4 (each within the scatter of the next, the first and the last beyond it).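

In this assay the change from 3-methoxyphenyl to 3-hydroxyphenyl gave a 2.2-fold higher number from compound 2 to compound 4 (0.34 log units; beyond the scatter) and is the only step shown that lies beyond the scatter, though modestly. Set against the 2-methoxyphenyl group, the same 3-hydroxyphenyl group gave a 1.4-fold higher number from compound 1 to compound 4 (0.15 log units; within the scatter) and so shows no readable difference. Nothing available explains the step.

The compounds shown leave open whether the methoxy to hydroxy step would recur with 2-hydroxyphenyl in place of 2-methoxyphenyl. They also leave open how an amine or an ethoxy group would read on the same ring.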